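A Fluorine Added to an Already Inactive Scaffold

A few compounds are considered here, and "the series" means these few. Any claim that something is new, unique, unknown or untested is made for them only; others in the source may bear on it.

Compound 1 `O=C(Nc1ccc(Oc2ccnc3[nH]ccc23)c(F)c1)c1nn(-c2ccc(Cl)cc2)ccc1=O`: > 60000 nM
Compound 2 `Cn1ccc2c(Oc3ccc(NC(=O)c4nn(-c5ccc(Cl)cc5)ccc4=O)cc3)ccnc21`: > 60000 nM

In a functional assay on MCF7 cells (Homo sapiens) for cytotoxicity, read by MTT assay, with a stated time of 72 h (a higher number here means a weaker inhibitor, a lower number a stronger inhibitor), compound 1 gives > 60000 nM, which is a limit of the assay rather than a measured number. In this assay compound 2 likewise gives > 60000 nM, again a limit and not a number. Among the measured compounds shown here, both of the values shown thus sit at the same limit, (the limit of > 60000 nM in this assay, at which 2 of the 2 values shown sit), so compound 2 cannot be placed higher or lower than compound 1 on these numbers, and no step between measured compounds can be drawn from them.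

Compound 3 `Cn1ccc2c(Oc3ccc(NC(=O)c4nn(-c5ccc(Cl)cc5)ccc4=O)cc3F)ccnc21` differs from compound 2 by fluoro in place of hydrogen on an aromatic carbon, in words fluoro in place of hydrogen on an aromatic carbon. With nothing but two limits to go on, the data offer no direction for this change in this assay, and no step beyond the usual scatter is expected. Compound 3 is therefore expected to come out near 70000 nM, most likely reported once more as a limit. The expected step in this assay is a step that the limit leaves unreadable from compound 2 to compound 3, which is no change beyond the scatter.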

Compound 3, half-maximal inhibitory concentration: > 60000 nM
Compound 3 gave a limit, no number (the forecaster's own chance of this, stated with the estimate: 85%); the middle value lies beyond the limit too.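

In this assay compound 3 gives > 60000 nM, which is a limit and not a number. No step can be read from compound 2 to compound 3 or from compound 1 to compound 3, because all three compounds share one limit: the limit of > 60000 nM in this assay, at which 3 of the 3 values shown sit. On these data alone, whether fluoro in place of hydrogen, or methyl in place of hydrogen on an aromatic nitrogen, changes the activity of this series at all remains open.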